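Side-Chain Swap Repeated on a Free Acid

The source may hold more compounds than are shown below. What is called first, only, known or untested is meant among the compounds shown, and "the series" means these compounds.

Compound 2, `NCCCC[C@H](NC(=O)CN(c1nc(Cl)nc2[nH]cnc12)C1CC1)C(=O)OCc1ccccc1`, carries a 4-aminobutyl group and a benzyl ester; in a functional assay on the whole organism (Tail, strain ICR) with Mus musculus as the target, in the tail flick test, with a stated time of 30 min, at a dose of 25 umol/kg by the oral route (on this read-out higher numbers stand for a stronger effect at the one dose given and lower numbers for a weaker effect), compound 2 gives 26.1%. Compound 1, `CC(C)[C@H](NC(=O)CN(c1nc(Cl)nc2[nH]cnc12)C1CC1)C(=O)OCc1ccccc1`, differs from it only in that (isopropyl in place of 4-aminobutyl on a saturated chain carbon bound to an amide-type nitrogen and a carbonyl carbon). In this assay compound 1 gives 33.4%, so the step is a number 7.3 percentage points higher from compound 2 to compound 1 (within the scatter).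

Compound 3, `NCCCC[C@H](NC(=O)CN(c1nc(Cl)nc2[nH]cnc12)C1CC1)C(=O)O`, is the free acid of compound 2: the two cores differ in that (hydrogen in place of benzyl on an oxygen next to a carbonyl group). In this assay compound 3 gives 31.2%, and the step is a number 5.1 percentage points higher from compound 2 to compound 3 (within the scatter). Compound 3 and compound 1 have not been compared as a step; their two values sit close to one another, and all three measured numbers lie within the usual scatter of each other.

Compound 4, `CC(C)[C@H](NC(=O)CN(c1nc(Cl)nc2[nH]cnc12)C1CC1)C(=O)O`, has not yet been tested. It stands to compound 3 as compound 1 stands to compound 2: isopropyl in place of 4-aminobutyl on a saturated chain carbon bound to an amide-type nitrogen and a carbonyl carbon. The place of this change is worded identically in both pairs, so it is the same change made on a different core, once on the benzyl ester and once on the free acid. Since the earlier step was a number 7.3 percentage points higher from compound 2 to compound 1 (within the scatter) and lay within the scatter, the step in this assay from compound 3 to compound 4 is expected to be of similar size, a number 5.8 percentage points higher from compound 3 to compound 4 (within the scatter), resting on that single precedent and on the small spread among compounds 1, 2 and 3. Compound 4 is therefore estimated to give 37% in this assay, with a range from 24% to 50%.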

Compound 4, a percentage reported as activity, at one dose (the size of the read-out at that dose, not a potency): 31.2%
For compound 4 the middle estimate is 5.8 percentage points above the measured one, and the stated range covers the measured number.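

Carried onto the free acid, isopropyl in place of 4-aminobutyl gives no change at the digits printed from compound 3 to compound 4 (within the scatter) in this assay, and the change cannot be told apart on the two cores: the same change on two cores in this assay, a number 7.3 percentage points higher (within the scatter) from compound 2 to compound 1 and no change at the digits printed (within the scatter) from compound 3 to compound 4, 7.3 percentage points apart, within the scatter of two such steps. Hydrogen in place of benzyl on the isopropyl compound gives a number 2.2 percentage points lower from compound 1 to compound 4 (within the scatter), and this change likewise cannot be told apart from its counterpart on the 4-aminobutyl compounds: the same change on two cores in this assay, a number 5.1 percentage points higher (within the scatter) from compound 2 to compound 3 and a number 2.2 percentage points lower (within the scatter) from compound 1 to compound 4, 7.3 percentage points apart, within the scatter of two such steps. So neither change produces a step on either core that stands clear of the usual scatter, and nothing here suggests that the core alters the outcome; however, steps this small do not show that the change transfers with the same size, nor that the two changes add up, and they say nothing about effects at any other dose or time.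

Left open is whether a side chain of another kind, such as a longer alkyl chain, a phenyl ring or a carboxylic acid, would give a step beyond the scatter on the benzyl ester or the free acid. Also open, on these data alone, is whether a small alkyl ester such as an ethyl ester would behave like the benzyl ester or like the free acid.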